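Replacing the chloropyridinyl sulfonyl group with a dimethylphenyl ring

The source may hold more compounds than are shown below. What is called first, only, known or untested is meant among the compounds shown, and "the series" means these compounds.

The series shares a core in which a piperidine bearing a methylpiperidinyl substituent carries an arylsulfonyl group on its ring nitrogen. Compound 1 `CC1CCN(C2CCN(S(=O)(=O)c3cccc(Br)c3)CC2)CC1` is the reference point: in a functional assay on DLD-1 cells (Homo sapiens) for antiproliferative activity, read by CellTiter-Glo, with a stated time of 72 h (on this read-out lower numbers stand for stronger inhibition and higher numbers for weaker inhibition), compound 1 gives 3.2 nM. Compound 2 `CCc1ccc(S(=O)(=O)N2CCC(N3CCC(C)CC3)CC2)cc1` sits at a limit of the assay. In this assay compound 2 gives > 5000 nM. Compound 3 `CC1CCN(C2CCN(S(=O)(=O)c3cccnc3Cl)CC2)CC1` likewise stands only at a limit. In this assay compound 3 gives > 5000 nM. The steps of an at least 1500-fold higher number from compound 1 to compound 2 (3.19 log units; beyond the scatter) and an at least 1500-fold higher number from compound 1 to compound 3 (3.19 log units; beyond the scatter) are both far beyond the scatter, and the step that the two limits leave unreadable from compound 2 to compound 3 cannot be read, since both ends rest on (the limit of > 5000 nM in this assay, at which 2 of the 3 values shown sit).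

Compound 4 `Cc1ccc(S(=O)(=O)N2CCC(N3CCC(C)CC3)CC2)cc1C` arises from compound 3 by the change (3,4-dimethylphenyl in place of 2-chloropyridin-3-yl on a sulfonyl sulfur). The change brings compound 4 close to compound 2, whose aryl group is also a carbon-only ring with an alkyl substituent, and compound 2 sits at the limit. He therefore expects the step that the limit leaves unreadable from compound 3 to compound 4 to be unreadable, with compound 4 most likely remaining at the limit. His estimate for compound 4 in this assay is 8000 nM, between 2000 nM and 30000 nM.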

Compound 4, half-maximal inhibitory concentration: 24 nM
The estimate for compound 4 lay 330-fold (2.52 log units) above the measured number, outside the stated range (below it).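

In this assay, 3,4-dimethylphenyl on the sulfonyl sulfur gives an at least 200-fold lower number from compound 3 to compound 4 (2.31 log units; beyond the scatter) and an at least 200-fold lower number from compound 2 to compound 4 (2.31 log units; beyond the scatter), so a carbon-only ring with alkyl substituents does not by itself sit at the limit, as the 4-ethylphenyl group had suggested. From the compounds shown here alone, both of these steps start from a limit, so their true size stays unknown: the limit of > 5000 nM in this assay, at which 2 of the 4 values shown sit. The 3-bromophenyl group still holds the lead, with a 7.5-fold higher number from compound 1 to compound 4 (0.88 log units; beyond the scatter), which makes this position sensitive to the aryl group's substitution rather than to one group alone.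

Which of the two methyl groups of compound 4 carries the gain stays open. Also open, going by these compounds, is whether a methoxy group, a trifluoromethyl group or an amine on the phenyl ring would keep the number this low.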